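Ring methylation: a step forward from compound 2

This account rests on a few compounds, and the source may have more. Where it says the series, first, only, none or still open, it means among the compounds named here.

In a functional assay on MCF7 cells (Homo sapiens) for cytotoxicity, read by MTT assay, with a stated time of 72 h (a lower number here means a stronger inhibitor, a higher number a weaker inhibitor), compound 2 `N/C(=N\NC(=S)N1CCOCC1)c1ccccn1` gives 4700 nM, the second highest of the three numbers recorded. Compound 3 `N/C(=N\NC(=S)N1CCCC1)c1ccccn1` gives 3600 nM, and the step of a 1.3-fold lower number from compound 2 to compound 3 (0.12 log units; within the scatter) sits within the scatter. Compound 1 `N/C(=N\NC(=S)N1CCOCC1)c1ccc(F)cn1` gives 22100 nM; the step of a 4.7-fold lower number from compound 1 to compound 2 (0.67 log units; beyond the scatter) is the only one that concerns the six-membered aromatic ring. Compound 4 `Cc1cccc(/C(N)=N/NC(=S)N2CCOCC2)n1` differs from compound 2 by methyl in place of hydrogen on an aromatic carbon. The earlier ring step involved a different group at a different place, so its direction cannot simply be carried over, while the pyrrolidin-1-yl step speaks to the thiocarbonyl carbon rather than the ring. Compound 4 is therefore expected to move little, a 1.1-fold higher number from compound 2 to compound 4 (0.03 log units; within the scatter), and its number in this assay is estimated at 5000 nM within 1500 nM to 16000 nM.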

Compound 4, half-maximal inhibitory concentration: 21500 nM
Compound 4: the middle estimate sits 4.3-fold (0.63 log units) below what was measured, outside the stated range (above it).
By their numbers in this assay, from the lowest: compounds 3 and 2 (each within the scatter of the next); then compounds 4 and 1 (each within the scatter of the next).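

In this assay methyl in place of hydrogen next to the ring nitrogen is no neutral change, giving a 4.6-fold higher number from compound 2 to compound 4 (0.66 log units; beyond the scatter) at this single aromatic carbon. The ring therefore responds here to one added methyl, and hydrogen carries the lower number at this position. The fluoro step, a 4.7-fold lower number from compound 1 to compound 2 (0.67 log units; beyond the scatter), points the same way from a different ring place. No measurement at hand accounts for this shift.

Going by these compounds, whether an amine or a methoxy group at this carbon would behave like methyl remains open. So does whether methyl here would shift compound 3 by a similar step.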